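This account rests on a few compounds, and the source may have more. Where it says the series, first, only, none or still open, it means among the compounds named here.

Series notes. The shared core carries a thioether side chain ending on a carbonyl carbon and an aryl group on the core nitrogen. Compound 1 `COc1ccc(-n2c(SCC(=O)c3ccc4ccccc4c3)nnc2-c2cc(OC)c(OC)c(OC)c2)cc1` gives 53400 nM in a functional assay on HT-29 cells (Homo sapiens) for inhibition, read by MTT assay, with a stated time of 48 h; on this read-out higher numbers stand for weaker inhibition and lower numbers for stronger inhibition. Compound 2 `CCOC(=O)CSc1nnc(-c2cc(OC)c(OC)c(OC)c2)n1-c1ccc(OC)cc1` returns only > 60000 nM in this assay, which is a limit of the assay and not a number. Compound 3 `COc1ccc(-n2c(SCC(=O)Nc3ccc(Cl)cc3)nnc2-c2cc(OC)c(OC)c(OC)c2)cc1` gives 58000 nM in this assay; of the two numbers shown it stands highest, with compound 1 nearest, and the step of a 1.1-fold higher number from compound 1 to compound 3 (0.04 log units; within the scatter) lies within the scatter. The other measured steps, an at least 1.1-fold higher number from compound 1 to compound 2 (0.05 log units; that floor lies within the scatter) and an at least 1.0-fold lower number from compound 2 to compound 3 (0.01 log units; that floor lies within the scatter), likewise do not pass the scatter. Compound 2 sits at the limit of > 60000 nM in this assay, at which 1 of the 3 values shown sits.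

Compound 4 `COc1cc(-c2nnc(SCC(=O)Nc3ccc(Cl)cc3)n2-c2ccc(N(C)C)cc2)cc(OC)c1OC` differs from compound 3 as follows: dimethylamino in place of methoxy on an aromatic carbon. Among the measured compounds shown here, all three measured steps alter the group on the carbonyl carbon; none touches the aryl group on the core nitrogen, so no measured step bears directly on this change. With every value shown near the upper end of this assay, no step beyond the scatter is expected in this assay for the change from compound 3 to compound 4, the expected step being a 1.1-fold lower number from compound 3 to compound 4 (0.02 log units; within the scatter). Compound 4 is estimated at 55000 nM in this assay, within 20000 nM to 60000 nM, with a fair chance that only a limit is returned.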

Compound 4, half-maximal inhibitory concentration: > 60000 nM
Compound 4: no number, only a limit; the forecaster's own chance of this, stated with the estimate: 40%; middle value at least 1.0-fold (0.03 log units) from the limit.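

Among the compounds shown here, at the aryl group on the core nitrogen, the change from 4-methoxyphenyl to 4-(dimethylamino)phenyl gives the first reading away from the carbonyl end of the side chain, and in this assay it comes out as an at least 1.0-fold higher number from compound 3 to compound 4 (0.01 log units; that floor lies within the scatter), which is only a floor. Compound 4 gives > 60000 nM, which is a limit of the assay and not a number. This position therefore shows no step beyond the scatter, as the carbonyl end did before it, and the series now gathers further at the top of the range of this assay: the limit of > 60000 nM in this assay, at which 2 of the 4 values shown sit.

From the compounds shown here alone, it remains open whether any other group on this aryl ring, such as a primary amine, a carboxylic acid or a longer alkoxy chain, would bring a value clearly down from that top end of the range. Also open, going by these compounds, is whether the same change from methoxy to dimethylamino would read differently with the naphthalen-2-yl group of compound 1 on the carbonyl carbon.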